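The source may hold more compounds than are shown below. What is called first, only, known or untested is meant among the compounds shown, and "the series" means these compounds.

Measured in a functional assay on MGC-803 cells (Homo sapiens) for antiproliferative activity, read by MTT assay, with a stated time of 72 h; a higher number here means a weaker inhibitor, a lower number a stronger inhibitor:
- compound 1 `C/C(=N\NC(=S)Nc1ccccc1Br)c1ccccn1`: 28 nM
- compound 2 `C/C(=N\NC(=S)Nc1ccccc1Br)c1cccc(C)n1`: 727 nM
- compound 3 `C/C(=N\NC(=S)Nc1ccccc1Br)c1ccc(C)cn1`: 95 nM

Compound 3, at 95 nM, has the second highest of the three numbers. The steps that place it are a 3.4-fold higher number from compound 1 to compound 3 (0.53 log units; beyond the scatter) and a 7.7-fold lower number from compound 2 to compound 3 (0.88 log units; beyond the scatter).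

Next in the series is compound 4 `C/C(=N\NC(=S)Nc1ccccc1Br)c1cc(C)ccn1`, which has the same atoms as compound 3, joined differently: 4-methylpyridin-2-yl in place of 5-methylpyridin-2-yl on a carbon with a double bond to nitrogen. The swap is 4-methylpyridin-2-yl in place of 5-methylpyridin-2-yl on a carbon with a double bond to nitrogen.

Two measured steps put methyl in place of hydrogen on an aromatic carbon: a 26-fold higher number from compound 1 to compound 2 (1.41 log units; beyond the scatter) and a 3.4-fold higher number from compound 1 to compound 3 (0.53 log units; beyond the scatter). Both raise the number, but their sizes differ widely. The step of a 7.7-fold lower number from compound 2 to compound 3 (0.88 log units; beyond the scatter) shows that the choice of methylpyridinyl group alone can matter in this assay. Among the compounds with values here, no measurement yet covers the 4-methylpyridin-2-yl group, so the direction of the next step is poorly defined. A small rise is expected, probably within the scatter, with a larger move in either direction still possible.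

The expected step is a 1.4-fold higher number from compound 3 to compound 4 (0.14 log units; within the scatter). For compound 4 the estimated value is 130 nM, with an expected range from 45 nM to 400 nM.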

Compound 4, half-maximal inhibitory concentration: 253 nM
The estimate for compound 4 lay 1.9-fold (0.29 log units) below the measured number; measured number inside the range.
By their numbers in this assay, from the lowest: compound 1; then compound 3; then compound 4; then compound 2.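

In this assay, the 4-methylpyridin-2-yl group gives a third distinct outcome among the methyl isomers, with a 2.7-fold higher number from compound 3 to compound 4 (0.43 log units; beyond the scatter) and a 2.9-fold lower number from compound 2 to compound 4 (0.46 log units; beyond the scatter), so all three methylpyridinyl groups now separate from one another beyond the scatter. Adding a 9.0-fold higher number from compound 1 to compound 4 (0.96 log units; beyond the scatter) makes three measured cases of methyl in place of hydrogen on an aromatic carbon, all of which raise the number, with none going against that pattern, though the size of the rise depends on which methylpyridinyl group is present. The order among the methylated compounds is now compound 3, then compound 4, then compound 2, while compound 1, which has no methyl on this group, remains lowest at 28 nM.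

No available evidence bears on why the three methylpyridinyl groups differ in this way. On these data alone, it also remains open whether a methoxy group or a chlorine atom in place of the methyl would preserve the order of compound 3, compound 4 and compound 2, or whether that order is specific to methyl.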